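Benzylamino for Isobutyl on the Carbonyl Carbon

The source may hold more compounds than are shown below. What is called first, only, known or untested is meant among the compounds shown, and "the series" means these compounds.

Of the compounds shown here, two have so far been measured in a functional assay on WI-38 VA13 cells (Homo sapiens) for cytotoxicity; on this read-out lower numbers stand for an effect already at smaller amounts and higher numbers for an effect only at larger amounts of compound. Compound 1 `CCCCOc1ccc(S(=O)(=O)Nc2ccc3nc(NC(=O)C4CCCCC4)sc3c2)cc1` gives 0.75 ug/mL. Compound 2 `CC(C)CC(=O)Nc1nc2ccc(NC(=O)c3c(Cl)cccc3Cl)cc2s1` gives 0.012 ug/mL, the lowest of the two numbers, and its nearest neighbour, compound 1, sits at a number beyond the scatter above it. Compound 3 `O=C(NCc1ccccc1)Nc1nc2ccc(NC(=O)c3c(Cl)cccc3Cl)cc2s1` is not yet measured; it differs from compound 2 in one place: benzylamino in place of isobutyl on a carbonyl carbon. Among the compounds with values here, no measured pair shows this change, so nothing in the data fixes its size or direction. A modest rise in the number is expected, with the step of a 2.5-fold higher number from compound 2 to compound 3 (0.40 log units; beyond the scatter) staying close to the scatter. Compound 3 is therefore expected at 0.03 ug/mL, within 0.005 ug/mL to 0.2 ug/mL.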

Compound 3, half-maximal effective concentration: 0.15 ug/mL
Estimate against measurement, compound 3: 5.0-fold (0.70 log units) below, and the stated range covers the measured number.
By their numbers in this assay, from the lowest: compound 2; then compound 3; then compound 1.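

In this assay, benzylamino in place of isobutyl on the carbonyl carbon gives a 13-fold higher number from compound 2 to compound 3 (1.10 log units; beyond the scatter), so the number at this position depends clearly on the group it carries. The entering group brings both a six-membered aromatic ring and a hydrogen-bond donor, and this single step cannot separate the two. No evidence on the reason for the step is at hand. Going by these compounds, it remains open whether a benzyl group without the nitrogen would read like compound 2 or compound 3. On these data alone, it also remains open where a simple ethylamino group would fall.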